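This account rests on a few compounds, and the source may have more. Where it says the series, first, only, none or still open, it means among the compounds named here.

For the measured compounds named here, compound 2 `Cc1cccc(NC(=O)Nc2ccc(Oc3ncnc4[nH]ncc34)cc2)c1C` is the only compound with an actual number in an assay on isolated protein for inhibition of vascular endothelial growth factor receptor 2 (Danio rerio), read by fluorescence and microscopy, with a stated time of 33 h; on this read-out higher numbers stand for weaker inhibition and lower numbers for stronger inhibition: compound 2 gives 98800 nM. Compound 1 `O=C(Nc1ccc(Nc2ncnc3[nH]ncc23)cc1)Nc1ccc(C(F)(F)F)cc1`, which also carries a 4-(trifluoromethyl)phenyl, gives > 100000 nM, which is a limit of this assay and not a number (the limit of > 100000 nM in this assay, at which 1 of the 2 values shown sits). Compound 3 `O=C(Nc1ccc(Oc2ncnc3[nH]ncc23)cc1)Nc1ccc(C(F)(F)F)cc1` differs from compound 2 by 4-(trifluoromethyl)phenyl in place of 2,3-dimethylphenyl on an amide-type nitrogen. The expected step of a 1.2-fold higher number from compound 2 to compound 3 (0.08 log units; within the scatter) is small, within the usual scatter of this assay. Compound 3 is expected to give 120000 nM, within a range from 40000 nM to 400000 nM, and quite possibly only a limit.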

Compound 3, half-maximal inhibitory concentration: 1200 nM
The estimate for compound 3 lay 100-fold (2.00 log units) above the measured number; measured number outside the range, below it.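

On an amide-type nitrogen, the choice of group can matter greatly: 4-(trifluoromethyl)phenyl in place of 2,3-dimethylphenyl gives an 82-fold lower number from compound 2 to compound 3 (1.92 log units; beyond the scatter) in this assay. With 4-(trifluoromethyl)phenyl kept, changing the group on an aromatic carbon gives an at least 83-fold lower number from compound 1 to compound 3 (1.92 log units; beyond the scatter). That step has no exact size, since compound 1 gives a limit of the assay and not a number: the limit of > 100000 nM in this assay, at which 1 of the 3 values shown sits.

The compounds shown leave open whether the trifluoromethyl group itself or its place on the ring accounts for the change. A plain phenyl or a 4-chlorophenyl on the same nitrogen could help separate the two.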